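Propyl against isopropyl on the azole nitrogen of the series

The source may report more compounds than this note shows. Statements on the series, on what has been measured and on what is new or still open speak of the compounds shown alone.

Working notes on four close analogues. Compound 1 `CCCn1ncnc1-c1ccccc1NCC1=NCCN1` carries a propyl group on an aromatic nitrogen of its five-membered ring, and in an in vitro functional assay on cells (Fibroblast) for agonist activity at Alpha-1B adrenergic receptor (Homo sapiens) (on this read-out higher numbers stand for an effect only at larger amounts of compound and lower numbers for an effect already at smaller amounts), compound 1 gives 316 nM as a measured number. Compound 2 `CC(C)n1ncnc1-c1ccccc1NCC1=NCCN1` differs from compound 1 by isopropyl in place of propyl on an aromatic nitrogen only. For compound 2 the value in this assay is a limit, < 100000 nM being recorded and no number. The step that the limit leaves unreadable from compound 1 to compound 2 therefore cannot be read in size, because the limit of < 100000 nM in this assay, at which 2 of the 3 values shown sit, covers the second value of the pair. Compound 3 `CCCn1nccc1-c1ccccc1NCC1=NCCN1` rests on a different core, and the difference between the two cores is not broken down here. In this assay compound 3 is likewise known only through a limit, < 100000 nM standing in place of a number. Compound 4 `CC(C)n1nccc1-c1ccccc1NCC1=NCCN1` has not been measured and differs from compound 3 by isopropyl in place of propyl on an aromatic nitrogen alone. This is the same kind of change as that from compound 1 to compound 2 but not the same change: around compound 1 the ring holds 3 nitrogen and the place lies two ring bonds from the ring nitrogen, whereas around compound 3 the ring holds 2 nitrogen. Among the measured compounds shown here, the one measured instance of the change ends at a limit, so no size can be carried over. For compound 4 the expected step that the limit leaves unreadable from compound 3 to compound 4 is accordingly set small and held with low confidence. Compound 4 is thus estimated at 30000 nM in this assay with a range from 3000 nM to 100000 nM around it, and a limit rather than a number is the likelier report.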

Compound 4, half-maximal effective concentration: < 100000 nM
Compound 4: no number, only a limit; the forecaster's own chance of this, stated with the estimate: 70%; the middle value does not contradict the limit.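

No size can be read for the change from compound 3 to compound 4 in this assay, because both compounds are known there only through a limit: the limit of < 100000 nM in this assay, at which 3 of the 4 values shown sit.

The compounds shown leave open how large the change of isopropyl in place of propyl on an aromatic nitrogen is on either core, with compound 1 the only one holding a measured number.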